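Replacing a cyclobutyl with a pentyl on the ring nitrogen

The source may hold more compounds than are shown below. What is called first, only, known or untested is meant among the compounds shown, and "the series" means these compounds.

Measured compounds:
Compound 1, `CCCNc1nc(SCc2ccc([N+](=O)[O-])cc2)c2ncn([C@@H]3O[C@H](CO)[C@@H](O)[C@H]3O)c2n1`, gives 193 nM in an assay on K562 cells for displacement of a labelled ligand from Equilibrative nucleoside transporter 1 (Homo sapiens), read by flow cytometry, with a stated time of 45 min; on this read-out lower numbers stand for stronger inhibition and higher numbers for weaker inhibition.
Compound 2, `O=[N+]([O-])c1ccc(CSc2nc(NC3CC3)nc3c2ncn3[C@@H]2O[C@H](CO)[C@@H](O)[C@H]2O)cc1`, gives 25 nM in this assay.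
Compound 3, `O=[N+]([O-])c1ccc(CSc2nc(NC3CCC3)nc3c2ncn3[C@@H]2O[C@H](CO)[C@@H](O)[C@H]2O)cc1`, gives 33 nM in this assay.

Compound 3 sits second highest of the three numbers; its nearest neighbour is compound 2, and the step of a 1.3-fold higher number from compound 2 to compound 3 (0.12 log units; within the scatter) lies within the scatter, while the step of a 5.8-fold lower number from compound 1 to compound 3 (0.77 log units; beyond the scatter) lies beyond it. Compound 4, `CCCCCNc1nc(SCc2ccc([N+](=O)[O-])cc2)c2ncn([C@@H]3O[C@H](CO)[C@@H](O)[C@H]3O)c2n1`, differs from compound 3 in one place: pentyl in place of cyclobutyl on a nitrogen on an aromatic ring. Among the measured compounds shown here, the steps that bear on this change are those from the propyl chain of compound 1 to the two cyclic groups, a 7.7-fold lower number from compound 1 to compound 2 (0.89 log units; beyond the scatter) and a 5.8-fold lower number from compound 1 to compound 3 (0.77 log units; beyond the scatter), both of which gave lower numbers when a ring replaced a chain. Compound 4 goes the other way, from a ring back to a chain, and a longer one than propyl, so a higher number is expected, roughly undoing part of that gain. Compound 4 is therefore estimated at 120 nM, within 40 nM to 400 nM, which would mean an expected step of a 3.6-fold higher number from compound 3 to compound 4 (0.56 log units; beyond the scatter).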

Compound 4, inhibition constant: 357 nM
Estimate against measurement, compound 4: 3.0-fold (0.47 log units) below; measured number inside the range.
By their numbers in this assay, from the lowest: compounds 2 and 3 (each within the scatter of the next); then compounds 1 and 4 (each within the scatter of the next).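

In this assay, the pentyl chain on this nitrogen lands far from the rings: the step of an 11-fold higher number from compound 3 to compound 4 (1.03 log units; beyond the scatter) and the step of a 14-fold higher number from compound 2 to compound 4 (1.15 log units; beyond the scatter) are both large, so cyclobutyl and cyclopropyl now stand apart from a second chain as well as from propyl. The two chains themselves are not told apart, with a 1.8-fold higher number from compound 1 to compound 4 (0.27 log units; within the scatter) as their step, so among these four compounds the divide runs between ring and open chain, and chain length adds nothing that can be read. No measurement shown gives a reason for this divide.

On these data alone, whether a branched chain such as isopropyl or tert-butyl reads with the rings or with the chains stays open. So does the place of a larger ring such as cyclopentyl or cyclohexyl.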